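The compounds below may be only part of what the source reports. "The series", "measured", "known", "first", "only" and "open" are said of these compounds alone.

Working notes on the series.

Compound 1 `O=C(Nc1cc(-c2ccccc2)nn1-c1ccccc1)c1ccc(Cl)cc1` carries a 4-chlorophenyl on the carbonyl carbon and in an assay on CHO cells with metabotropic glutamate receptor 5 (Homo sapiens) as the target (a lower number here means that less compound is needed, a higher number that more compound is needed for the effect), compound 1 gives 20 nM. Compound 2 `O=C(Nc1cc(-c2ccccc2)nn1-c1ccccc1)c1ccccc1O` differs only in the group on that carbonyl carbon. In this assay compound 2 gives > 10000 nM, which is a limit of the assay and not a number. Going by the values given here, the single measured step is therefore an at least 500-fold higher number from compound 1 to compound 2 (2.69 log units; beyond the scatter), and its true size is open because of the limit of > 10000 nM in this assay, at which 1 of the 2 values shown sits. Compound 2 thus sits at the weak end of the two values shown.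

Compound 3 `O=C(Nc1cc(-c2ccccc2)nn1-c1ccccc1)c1ccc(F)c(F)c1` is the next member. The change from compound 2 is 3,4-difluorophenyl in place of 2-hydroxyphenyl on a carbonyl carbon. Among the compounds with values here, the only measured step that bears on it is the one from compound 1 to compound 2, which was large and went toward a higher number when 2-hydroxyphenyl entered. Compound 3 returns to a halogen-substituted phenyl without hydroxyl, closer to compound 1 than to compound 2. The step from compound 2 to compound 3 is therefore expected to be large and toward a lower number, an at least 160-fold lower number from compound 2 to compound 3 (2.22 log units; beyond the scatter). For compound 3 in this assay the estimate is 60 nM, with a range of 15 nM to 400 nM.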

Compound 3, half-maximal effective concentration: 10 nM
For compound 3 the middle estimate is 6.0-fold (0.78 log units) above the measured one; the whole stated range lies above it.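

The steps around this carbonyl carbon now show that the weak reading in this assay is not shared by every substituted phenyl. The two halogen-bearing groups cannot be separated here, as the step is a 2.0-fold lower number from compound 1 to compound 3 (0.30 log units; within the scatter), so 3,4-difluorophenyl and 4-chlorophenyl serve equally well within this small set, and a change in the number and kind of halogen leaves the reading inside the usual scatter. Compound 2 now stands apart from both halogen-bearing compounds, with an at least 1000-fold lower number from compound 2 to compound 3 (3.00 log units; beyond the scatter) as a second large step alongside the first, but its value is a limit of the assay and not a number, so the true size of the step stays open because of this: the limit of > 10000 nM in this assay, at which 1 of the 3 values shown sits.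

The compounds shown leave open whether the weak reading of compound 2 belongs to the hydroxyl itself or to the whole 2-hydroxyphenyl group, and an unsubstituted phenyl or a methoxyphenyl on the same carbonyl carbon would bear on that question. They also leave open how far this position reaches beyond halogen-bearing phenyl groups, for instance to a nitrile-bearing phenyl, a carboxylic acid-bearing phenyl or an amine-bearing phenyl.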